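Swapping the aryl ring on the amidoxime of a nitrobenzofurazan

The compounds below may be only part of what the source reports. "The series", "measured", "known", "first", "only" and "open" are said of these compounds alone.

Of the compounds shown here, two sharing one core have been measured so far. Compound 1 `O=[N+]([O-])c1ccc(N/C(=N\O)c2ccccc2F)c2nonc12` gives 63 nM in an assay on isolated protein for inhibition of Indoleamine 2,3-dioxygenase 1 (Homo sapiens), read by spectrophotometry, with a stated time of 1 h; on this read-out lower numbers stand for stronger inhibition and higher numbers for weaker inhibition. For the measured compounds named here, compound 2 `O=[N+]([O-])c1ccc(N/C(=N\O)c2ccc(Br)cc2)c2nonc12` gives 117 nM in this assay, which is the higher of the two numbers, though the only known step, a 1.9-fold higher number from compound 1 to compound 2 (0.27 log units; within the scatter), lies within the scatter, so the two cannot be ranked. Compound 3 `O=[N+]([O-])c1ccc(N/C(=N\O)c2ccc(F)c(Cl)c2)c2nonc12` has not been measured; it differs from compound 2 by 3-chloro-4-fluorophenyl in place of 4-bromophenyl on a carbon with a double bond to nitrogen. Going by the values given here, the single step in hand bears on this change, since it also swaps the aryl ring at the same place, and it was small. The expectation for compound 3 in this assay is therefore no step beyond the scatter, estimated as a 1.2-fold lower number from compound 2 to compound 3 (0.07 log units; within the scatter). Compound 3 is thus estimated at 100 nM, with a range from 40 nM to 250 nM.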

Compound 3, half-maximal inhibitory concentration: 158 nM
Compound 3: the middle estimate sits 1.6-fold (0.20 log units) below what was measured, within the range that was stated.
By their numbers in this assay, from the lowest: compounds 1, 2 and 3 (each within the scatter of the next, the first and the last beyond it).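

In this assay, replacing 4-bromophenyl with 3-chloro-4-fluorophenyl gives a 1.4-fold higher number from compound 2 to compound 3 (0.13 log units; within the scatter) and so does not separate these two rings. For the compounds shown here, replacing 2-fluorophenyl with 3-chloro-4-fluorophenyl gives a 2.5-fold higher number from compound 1 to compound 3 (0.40 log units; beyond the scatter) and is the first step at this position to pass the scatter, showing that the choice of halogen-bearing phenyl ring can register here, though only modestly. Nothing available explains this difference between the rings.

From the compounds shown here alone, all three compounds carry a phenyl ring with halogen on it, so it remains open how the position responds to a plain phenyl ring or to one bearing a methoxy group. A ring carrying an amine or a carboxylic acid is also untested among the compounds shown, so the limits of what this position accepts are unknown.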